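Alkoxy chain length and HEK-293T cytotoxicity of three anilino-squaramides

A few compounds are considered here, and "the series" means these few. Any claim that something is new, unique, unknown or untested is made for them only; others in the source may bear on it.

Measured compounds: compound 1, `COc1cc(NC(C)CCCNc2c(NCCCC(C)Nc3cc(OC)cc4cccnc34)c(=O)c2=O)c2ncccc2c1`, "not determined" (no result reported); compound 2, `CCCCOc1c(NCCCCCNc2cc(OC)cc3cccnc23)c(=O)c1=O`, > 100000 nM; compound 3, `COc1cc(NC(C)CCCNc2c(OC)c(=O)c2=O)c2ncccc2c1`, "not determined" (no result reported).

In an ADME assay on HEK-293T cells (Homo sapiens) for cytotoxicity, read by MTT assay, with a stated time of 48 h (a higher number here means a weaker inhibitor, a lower number a stronger inhibitor), compound 3 has no single number; one other compound gives only a limit, and one other entry has no number at all. Compound 2 sits at the limit of > 100000 nM in this assay, at which 1 of the 3 values shown sits, a limit and not a measured value. Compound 4, `CCOc1c(NCCCC(C)Nc2cc(OC)cc3cccnc23)c(=O)c1=O`, differs from compound 3 only by methyl in place of hydrogen on a saturated chain carbon bound to an oxygen on an aromatic ring. Among the measured compounds shown here, no measured step of this kind exists here, so nothing shows the effect of a methyl added at this place. For the measured compounds named here, since the only reported value in this assay is a limit, no movement beyond the usual scatter is expected in either direction. Compound 4 is therefore estimated at 100000 nM, within 30000 nM to 300000 nM.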

Compound 4, half-maximal inhibitory concentration: > 100000 nM
Compound 4 was reported as a limit (the forecaster's own chance of this, stated with the estimate: 70%); the middle value lies on the limit itself.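

In this assay, among the compounds shown here, compound 4 gives > 100000 nM, which is a limit, so no step from compound 3 to compound 4 can be read. The compounds shown leave open whether methoxy to ethoxy shifts this read-out at all.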